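Swapping chloro for bromo in compound 3

The source may report more compounds than this note shows. Statements on the series, on what has been measured and on what is new or still open speak of the compounds shown alone.

Measured in a functional assay on HeLa cells (Homo sapiens) for cytotoxicity, read by sulforhodamine B assay (on this read-out higher numbers stand for weaker inhibition and lower numbers for stronger inhibition), so far:
- Compound 1 `Cc1ccc(S(=O)(=O)NC(C)C2=CC(=O)c3c(O)ccc(O)c3C2=O)cc1` gives 5340 nM
- Compound 2 `COc1ccc(S(=O)(=O)NC(C)C2=CC(=O)c3c(O)ccc(O)c3C2=O)cc1` gives 3760 nM
- Compound 3 `CC(NS(=O)(=O)c1ccc(Cl)cc1)C1=CC(=O)c2c(O)ccc(O)c2C1=O` gives 810 nM

Compound 3 has the lowest number of the three, and its steps to both others lie beyond the scatter, so it is the most potent so far. Compound 4 `CC(NS(=O)(=O)c1ccc(Br)cc1)C1=CC(=O)c2c(O)ccc(O)c2C1=O` differs from it in one place. The change is bromo in place of chloro on an aromatic carbon, para to a large group.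

Two measured steps end on the chloro group: a 6.6-fold lower number from compound 1 to compound 3 (0.82 log units; beyond the scatter) and a 4.6-fold lower number from compound 2 to compound 3 (0.67 log units; beyond the scatter). Both are modest and beyond the scatter. In contrast, a 1.4-fold lower number from compound 1 to compound 2 (0.15 log units; within the scatter) stays within it. None of these steps swaps one halogen for another, so they are only a loose guide. No step beyond the scatter is expected in this assay, and no direction is favoured. The expected step is a 1.1-fold lower number from compound 3 to compound 4 (0.03 log units; within the scatter) here. For compound 4 the estimate is 750 nM, with an expected range of 320 nM to 1700 nM.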

Compound 4, half-maximal inhibitory concentration: 5210 nM
The estimate for compound 4 lay 6.9-fold (0.84 log units) below the measured number; measured number outside the range, above it.
By their numbers in this assay, from the lowest: compound 3; then compounds 2, 4 and 1 (each within the scatter of the next).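

In this assay, this position separates two halogens: a 6.4-fold higher number from compound 3 to compound 4 (0.81 log units; beyond the scatter) shows that the low number of compound 3 goes with chloro itself, not with any halogen at this place. Bromo instead falls in with the two non-halogen groups, with a 1.4-fold higher number from compound 2 to compound 4 (0.14 log units; within the scatter) and a 1.0-fold lower number from compound 1 to compound 4 (0.01 log units; within the scatter) both within the scatter, so of the four groups only chloro stands apart. Nothing available here accounts for so large a gap between chloro and bromo.

Fluoro, iodo, nitrile and trifluoromethyl are not among the compounds shown, so it remains open whether any of them would match chloro on this aromatic carbon. As far as these compounds go, it also remains open whether chloro is a lone exception or one member of a wider set of groups giving low numbers.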